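The source may hold more compounds than are shown below. What is called first, only, known or untested is meant among the compounds shown, and "the series" means these compounds.

Working notes on the series. Compound 1 `CC(C)CN(Cc1ccc(C(=O)NO)cc1)S(=O)(=O)c1cc(F)c(F)c(F)c1F` carries isobutyl on the sulfonamide nitrogen. In an assay on Sf9 cells for inhibition of histone deacetylase 11 (Homo sapiens), read by fluorescence and mobility shift assay (a higher number here means a weaker inhibitor, a lower number a stronger inhibitor), compound 1 gives only a limit, > 1000 nM. Compound 2 `CC(C)N(Cc1ccc(C(=O)NO)cc1)S(=O)(=O)c1cc(F)c(F)c(F)c1F` carries isopropyl at the same position of the shared core. In this assay compound 2 likewise gives only a limit, > 1000 nM. The step that the two limits leave unreadable from compound 1 to compound 2 therefore cannot be sized, as both values sit at the same limit (the limit of > 1000 nM in this assay, at which 2 of the 2 values shown sit). Compound 2 thus stands at the limit, with no number beneath it to compare against.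

Compound 3 `O=C(NO)c1ccc(CN(C2CCCC2)S(=O)(=O)c2cc(F)c(F)c(F)c2F)cc1` is the next member; the change from compound 2 is cyclopentyl in place of isopropyl on a sulfonamide nitrogen. For the measured compounds named here, the only measured step that bears on this change is a step that the two limits leave unreadable from compound 1 to compound 2, and it is unreadable, so neither a direction nor a size in this assay follows from the measured pairs. With both measured members resting at the limit (the limit of > 1000 nM in this assay, at which 2 of the 2 values shown sit), the expectation for compound 3 is a value again at or past that limit, a readable number not being excluded. The expected step from compound 2 to compound 3 is a step that the limit leaves unreadable from compound 2 to compound 3. Compound 3 is accordingly estimated at 3000 nM, with a range from 800 nM to 15000 nM.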

Compound 3, half-maximal inhibitory concentration: > 1000 nM
Compound 3 gave a limit, no number; the forecaster's own chance of this, stated with the estimate: 85%; the middle value is on the limit's open side.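

Compound 3 gives > 1000 nM, a limit and not a number, so no new step can be read among compound 1, compound 2 and compound 3: the limit of > 1000 nM in this assay, at which 3 of the 3 values shown sit.

The compounds shown leave open how far past this limit each one lies in this assay, and whether any group on the sulfonamide nitrogen gives a readable number.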